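Swapping methoxy for nitro on the aryl amine

The compounds below may be only part of what the source reports. "The series", "measured", "known", "first", "only" and "open" are said of these compounds alone.

Values in a functional assay on DU-145 cells (Homo sapiens) for antiproliferative activity, read by CCK-8 assay, with a stated time of 72 h (on this read-out higher numbers stand for weaker inhibition and lower numbers for stronger inhibition), are as follows
Compound 1 (`Cc1cc(Nc2cc(N3CCN(C)CC3)nc(Nc3ccc([N+](=O)[O-])cc3)n2)n[nH]1`) gives 1200 nM
Compound 2 (`Cc1cc(Nc2cc(N3CCN(C)CC3)nc(Nc3ccc(Cl)cc3)n2)n[nH]1`) gives 2240 nM
Compound 3 (`COc1cccc(Nc2nc(Nc3cc(C)[nH]n3)cc(N3CCN(C)CC3)n2)c1`) gives 2650 nM

Compound 3 cannot be separated from compound 2 (a 1.2-fold higher number from compound 2 to compound 3 (0.07 log units; within the scatter)) but stands apart from compound 1 (a 2.2-fold higher number from compound 1 to compound 3 (0.34 log units; beyond the scatter)). Compound 4 (`Cc1cc(Nc2cc(N3CCN(C)CC3)nc(Nc3cccc([N+](=O)[O-])c3)n2)n[nH]1`) carries nitro in place of methoxy on an aromatic carbon. Among the measured compounds shown here, no measured compound has this 3-nitrophenyl group, so the evidence is indirect. The closest step runs from 4-nitrophenyl to 3-methoxyphenyl (a 2.2-fold higher number from compound 1 to compound 3 (0.34 log units; beyond the scatter)), and read backwards it suggests a somewhat lower number. Chloro in place of nitro stayed within the scatter (a 1.9-fold higher number from compound 1 to compound 2 (0.27 log units; within the scatter)), which also points to a small change. The expected step is modest (a 1.7-fold lower number from compound 3 to compound 4 (0.22 log units; within the scatter)) and towards a lower number. For compound 4 the estimated value is 1600 nM, with an expected range from 800 nM to 3200 nM in this assay.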

Compound 4, half-maximal inhibitory concentration: 1340 nM
Compound 4: middle estimate off by 1.2-fold (0.08 log units), on the high side; low and high end bracket the measured number.
By their numbers in this assay, from the lowest: compounds 1, 4, 2 and 3 (each within the scatter of the next, the first and the last beyond it).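

In this assay, nitro in place of methoxy stays within the scatter (a 2.0-fold lower number from compound 3 to compound 4 (0.30 log units; within the scatter)), so this swap alone cannot be said to change the result. The 3-nitrophenyl group also cannot be separated from 4-nitrophenyl (a 1.1-fold higher number from compound 1 to compound 4 (0.05 log units; within the scatter)) or from 4-chlorophenyl (a 1.7-fold lower number from compound 2 to compound 4 (0.22 log units; within the scatter)), so where the nitro sits makes no readable difference here. Nothing available explains these small steps. Still open, on these data alone, is whether an amine or a carboxylic acid on this aromatic ring would give a step beyond the scatter.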